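Bromo in place of isopropyl on a hydroxamate sulfonamide

The compounds below may be only part of what the source reports. "The series", "measured", "known", "first", "only" and "open" are said of these compounds alone.

Compound 1, `COc1ccc(S(=O)(=O)N(Cc2ccc(C(C)C)cc2)[C@H](C)C(=O)NO)cc1`: 230 nM
Compound 2, `C=CCOc1ccc2ccc(CN([C@H](C)C(=O)NO)S(=O)(=O)c3ccc(OC)cc3)cc2c1`: 130 nM

In an assay on isolated protein for inhibition of bone morphogenetic protein 1 (Homo sapiens) (a lower number here means a stronger inhibitor, a higher number a weaker inhibitor), compound 1 gives 230 nM and compound 2 gives 130 nM; the two numbers sit within the usual scatter of each other, so neither stands apart. Compound 3, `COc1ccc(S(=O)(=O)N(Cc2ccc(Br)cc2)[C@H](C)C(=O)NO)cc1`, has not been measured. It differs from compound 1 by one change: bromo in place of isopropyl on an aromatic carbon. Among the compounds with values here, no measured pair shows this change, so its effect is unknown. The step from compound 1 to compound 3 is expected to be small, a 1.3-fold higher number from compound 1 to compound 3 (0.12 log units; within the scatter), not beyond the scatter. Compound 3 is therefore expected near 300 nM, between 100 nM and 900 nM.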

Compound 3, half-maximal inhibitory concentration: 37 nM
The estimate for compound 3 lay 8.1-fold (0.91 log units) above the measured number, outside the stated range (below it).
By their numbers in this assay, from the lowest: compound 3; then compounds 2 and 1 (each within the scatter of the next).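

In this assay, the change from 4-isopropylphenyl to 4-bromophenyl gives a 6.2-fold lower number from compound 1 to compound 3 (0.79 log units; beyond the scatter) and so shows that this position, on an aromatic carbon para to a large group, responds to what sits on it. The earlier compounds shown here differed in more than one place and could not show this. Nothing available explains the gain. From the compounds shown here alone, whether it belongs to bromine itself or to the loss of isopropyl stays open. The compounds shown hold no chloro, methyl, methoxy or amine at this place to separate the two.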